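A Small Pyrazole Exchange on a Stable Compound

A few compounds are considered here, and "the series" means these few. Any claim that something is new, unique, unknown or untested is made for them only; others in the source may bear on it.

In an ADME assay on microsomes from liver (Mus musculus) for metabolic stability, with a stated time of 30 min, tested at 1 uM (a lower number here means that less of the compound is left, a higher number that more of the compound is left), compound 1 (`CCN1CCN(C(=O)c2ccc(Nc3ncc4c(n3)N(C)C(=O)N(c3cc(NC(=O)c5cccc(C(F)(F)F)c5)ccc3C)C4)cn2)CC1`) gives 24.2% as its result. In this assay compound 2 (`Cc1ccc(NC(=O)c2cccc(C(F)(F)F)c2)cc1N1Cc2cnc(Nc3cnn(C)c3)nc2N(C)C1=O`) gives 73.3% and so holds the higher of the two numbers, by a gap well beyond the usual scatter. Compound 3 (`Cc1cc(Nc2ncc3c(n2)N(C)C(=O)N(c2cc(NC(=O)c4cccc(C(F)(F)F)c4)ccc2C)C3)n(C)n1`) has not been measured yet. It differs from compound 2 by a single exchange (1,3-dimethyl-1H-pyrazol-5-yl in place of 1-methyl-1H-pyrazol-4-yl on a nitrogen on an aromatic ring): 1,3-dimethyl-1H-pyrazol-5-yl in place of 1-methyl-1H-pyrazol-4-yl on a nitrogen on an aromatic ring. Going by the values given here, no two measured compounds differ by one exchange alone, so the data give no direct guide to its effect. The starting point is the only firm clue: compound 2 at 73.3% on this scale has more room to fall than to rise. The expected change is a modest fall, with a number 11.3 percentage points lower from compound 2 to compound 3 (beyond the scatter) as the estimated step, close to the edge of the usual scatter. For compound 3 the estimated value is 62% with an expected range from 40% to 82% in this assay once it is measured.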

Compound 3, percent of the compound remaining: 74.7%
Compound 3: middle estimate off by 12.7 percentage points, on the low side; the range from low to high includes it.
By their numbers in this assay, from the lowest: compound 1; then compounds 2 and 3 (each within the scatter of the next).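

In this assay, going by these compounds alone, exchanging 1-methyl-1H-pyrazol-4-yl, which sits on a nitrogen on an aromatic ring, for 1,3-dimethyl-1H-pyrazol-5-yl gives a number 1.4 percentage points higher from compound 2 to compound 3 (within the scatter) and this is the first direct reading of a single exchange at this position. It shows that this position accepts a change from a group of 6 heavy atoms to one of 7, with a different attachment point on the pyrazole and an added methyl, without a shift that can be told apart from the scatter of repeated measurements. Nothing available explains why the two pyrazoles give such similar results.

Going by these compounds, what remains open is how far this tolerance extends, since both groups compared here are methylated pyrazoles, and a morpholine, a carboxylic acid or a longer chain such as 1-propyl on the pyrazole could behave quite differently at the same nitrogen. Within the data shown here, the single step also says nothing about other parts of the molecule, such as whether a nitrile in place of the trifluoromethyl group would leave the percentage remaining in this assay unchanged.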